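A few compounds are considered here, and "the series" means these few. Any claim that something is new, unique, unknown or untested is made for them only; others in the source may bear on it.

Of the compounds shown here, three built on one shared core have been measured in a functional assay on HT cells (Homo sapiens) for antiproliferative activity, read by fluorescence, with a stated time of 72 h; a lower number here means a stronger inhibitor of growth, a higher number a weaker inhibitor of growth. Compound 1 `CC(C)c1n[nH]c2c(NCc3ccc(-c4ccccn4)cc3)nc(SCC(O)C(F)(F)F)nc12` gives 690 nM. Compound 2 `CC(C)c1n[nH]c2c(NCc3ccc(-c4ccccn4)cc3)nc(SCC(O)CN)nc12` gives 55 nM. Compound 3 `CC(C)c1n[nH]c2c(NCc3ccc(-c4ccccn4)cc3)nc(SCC(N)=O)nc12` gives 192 nM. Among these three numbers compound 3 stands second highest: compound 2 lies nearest to it and compound 1 furthest from it. The measured steps are a 13-fold lower number from compound 1 to compound 2 (1.10 log units; beyond the scatter), a 3.6-fold lower number from compound 1 to compound 3 (0.56 log units; beyond the scatter) and a 3.5-fold higher number from compound 2 to compound 3 (0.54 log units; beyond the scatter).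

Compound 4 `CC(C)c1n[nH]c2c(NCc3ccc(-c4ccccn4)cc3)nc(SCC(O)CO)nc12` has not yet been measured. It differs from compound 3 in one place: 1,2-dihydroxyethyl in place of carbamoyl on a saturated chain carbon bound to a sulfur. Going by the values given here, two measured steps bear on this change, since each exchanges the group on a saturated chain carbon bound to a sulfur. The step from a 2-amino-1-hydroxyethyl to carbamoyl was modest, and the step from a 2,2,2-trifluoro-1-hydroxyethyl to carbamoyl was modest in the other direction. The 1,2-dihydroxyethyl of compound 4 resembles the hydroxy-bearing chain of compound 2 more than that of compound 1, so a modest step downward is expected rather than none. Compound 4 is therefore estimated to give 100 nM, with a likely range from 40 nM to 250 nM. The expected step is a 1.9-fold lower number from compound 3 to compound 4 (0.28 log units; within the scatter).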

Compound 4, concentration for 50% growth inhibition: 21 nM
Estimate against measurement, compound 4: 4.8-fold (0.68 log units) above; the measured number lies below the stated range.
By their numbers in this assay, from the lowest: compound 4; then compound 2; then compound 3; then compound 1.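

Going by these compounds alone, exchanging carbamoyl for 1,2-dihydroxyethyl on a saturated chain carbon bound to a sulfur gives a 9.1-fold lower number from compound 3 to compound 4 (0.96 log units; beyond the scatter) in this assay, so this position responds more strongly to the exchange than the earlier compounds had suggested. The amino group of compound 2 is not needed for a low number here: hydroxy in place of amino gives a 2.6-fold lower number from compound 2 to compound 4 (0.42 log units; beyond the scatter), and hydroxymethyl in place of trifluoromethyl gives a 33-fold lower number from compound 1 to compound 4 (1.52 log units; beyond the scatter). Among the three chains that carry a hydroxy group, the one with the second hydroxy group, in compound 4, therefore gives the lowest number, ahead of the amino chain of compound 2 and the trifluoromethyl chain of compound 1.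

Nothing given here accounts for this order, and no separate measurement bears on it. On these data alone, it remains open whether both hydroxy groups of the 2,3-dihydroxypropyl chain contribute, as a 2-hydroxyethyl chain with only one of them would test, and how a carboxylic acid in place of carbamoyl or a longer chain such as 3,4-dihydroxybutyl would fare.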